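The compounds below may be only part of what the source reports. "The series", "measured", "known", "first", "only" and "open" are said of these compounds alone.

Measured so far in an ADME assay on microsomes from liver (Homo sapiens) for metabolic stability, read by LC-MS, using NADPH, with a stated time of 45 min, tested at 3 uM; on this read-out higher numbers stand for a longer-lived compound and lower numbers for a shorter-lived compound:
- Compound 1 `C1CCC(C(CC2CCCCN2)C2CCC2)CC1`: > 3.33 h, a limit
- Compound 2 `C1CCC(C(CC2CCCCN2)C2CCCC2)CC1`: > 2.5 h, a limit
- Compound 3 `C1CCC(CC(C2CCCC2)C2CC2)NC1`: 0.45 h, a number

Compound 3 stands at 0.45 h in this assay. Going by the values given here, this is the only true number in the set, as the other two values are limits.

Compound 4 `C1CCC(CC(C2CCCC2)C2CCC2)NC1` differs from compound 3 in one place: cyclobutyl in place of cyclopropyl on a saturated chain carbon bound to a saturated chain carbon and a saturated ring carbon.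

Among the compounds with values here, two measured steps touch this place. The more informative is an at least 5.5-fold lower number from compound 2 to compound 3 (0.74 log units; beyond the scatter), which came with cyclopropyl in place of cyclohexyl. The other, a step that the two limits leave unreadable from compound 1 to compound 2, gives no size, so it cannot show how much the half-life responds to a change from cyclobutyl to cyclopentyl. Neither compound 1 nor compound 2 carries cyclopropyl, and compound 1 carries the cyclobutyl that compound 4 would have. Compound 4 is therefore expected to regain part of the loss seen in an at least 5.5-fold lower number from compound 2 to compound 3 (0.74 log units; beyond the scatter), though probably not all of it. A modest rise is expected, with an estimated 2.2-fold higher number from compound 3 to compound 4 (0.35 log units; beyond the scatter). For compound 4 the estimated half-life is 1 h, with an expected range of 0.45 h to 2.5 h.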

Compound 4, half-life: 0.85 h
Compound 4: the middle estimate sits 1.2-fold (0.07 log units) above what was measured; measured number inside the range.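

In this assay, cyclobutyl in place of cyclopropyl on a saturated chain carbon bound to a saturated chain carbon and a saturated ring carbon gives a 1.9-fold higher number from compound 3 to compound 4 (0.28 log units; within the scatter), so the extra ring carbon does not separate these two compounds. Cyclobutyl in place of cyclohexyl gives an at least 2.9-fold lower number from compound 2 to compound 4 (0.46 log units; beyond the scatter), and cyclopentyl in place of cyclohexyl gives an at least 3.9-fold lower number from compound 1 to compound 4 (0.59 log units; beyond the scatter), which shows that the lower half-life follows the loss of cyclohexyl from this place and is not tied to cyclopropyl alone, since compound 4 carries no cyclopropyl and still sits lower than both compounds with cyclohexyl. The step from compound 2 gives only a minimum size, as the value of compound 2 is a limit: the limit of > 2.5 h in this assay, at which 1 of the 4 values shown sits.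

Going by these compounds, the step from compound 1 likewise gives only a minimum size, and the full gap to compound 4 stays open, as the value of compound 1 is also a limit: the limit of > 3.33 h in this assay, at which 1 of the 4 values shown sits. It also remains open whether a phenyl ring or a cycloheptyl group in this place would match the half-life seen with cyclohexyl, or whether cyclohexyl is alone in doing so among such rings.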